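The source may hold more compounds than are shown below. What is called first, only, known or untested is meant among the compounds shown, and "the series" means these compounds.

Compound 1 `CCC(C)N(c1ccnc(Nc2ccc(C#N)cc2)n1)c1c(F)cc(-c2ccc(C#N)cc2)cc1F` gives 217000 nM in an ADME assay on MT4 cells (Homo sapiens) for cytotoxicity, read by MTT assay, with a stated time of 5 days; on this read-out higher numbers stand for lower toxicity in this test and lower numbers for higher toxicity in this test. Compound 2 `N#Cc1ccc(Nc2nccc(N(CCCCl)c3c(F)cc(-c4ccc(C#N)cc4)cc3F)n2)cc1` gives only a limit in this assay, > 250000 nM, so where it stands is known just as that limit. For the measured compounds named here, the single measured step, an at least 1.1-fold higher number from compound 1 to compound 2 (0.06 log units; that floor lies within the scatter), is the one that bears on what follows, and its floor comes from the limit of > 250000 nM in this assay, at which 1 of the 2 values shown sits. Compound 3 `N#CCN(c1ccnc(Nc2ccc(C#N)cc2)n1)c1c(F)cc(-c2ccc(C#N)cc2)cc1F` differs from compound 2 by cyano in place of 2-chloroethyl on a saturated chain carbon bound to a nitrogen on an aromatic ring. Going by the values given here, since the one measured step sits within the scatter and no measured step covers a cyano group, no change beyond the scatter is expected, an at least 1.1-fold lower number from compound 2 to compound 3 (0.05 log units; that floor lies within the scatter). Compound 3 is therefore estimated at 220000 nM, in the range 90000 nM to 250000 nM.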

Compound 3, half-maximal cytotoxic concentration: 206000 nM
The estimate for compound 3 lay 1.1-fold (0.03 log units) above the measured number; the measured number falls inside the stated range.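

Cyanomethyl in place of sec-butyl on this nitrogen gives a 1.1-fold lower number from compound 1 to compound 3 (0.02 log units; within the scatter) and so brings no change beyond the scatter in this assay, which the earlier compounds, with no nitrile on this chain, could not show. Cyano in place of 2-chloroethyl gives an at least 1.2-fold lower number from compound 2 to compound 3 (0.08 log units; that floor lies within the scatter) and adds no change that can be read beyond the scatter. That step is only a floor, since the value of compound 2 is a limit: the limit of > 250000 nM in this assay, at which 1 of the 3 values shown sits.

Going by these compounds, whether an amine, a carboxylic acid or a longer chain on this nitrogen would behave the same stays open. So does whether this holds on any other core.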